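The compounds below may be only part of what the source reports. "The series", "measured", "known", "first", "only" and "open" are said of these compounds alone.

Of the compounds shown here, three built on one shared core have been measured in an assay on isolated protein for inhibition of Nitric oxide synthase, inducible (Homo sapiens), read by scintillation counting, with a stated time of 30 min, tested at 50 uM; a lower number here means less inhibition, a higher number more inhibition at the concentration tested (going by the name of the read-out). Compound 1 `CCC(=O)N1N=C(c2cc(OC)ccc2N)SC1(C)C` gives 73%. Compound 2 `CCCC(=O)N1N=C(c2cc(OC)ccc2N)SC1(C)C` gives 91.1%. Compound 3 `COc1ccc(N)c(C2=NN(C(=O)C3CC3)C(C)(C)S2)c1` gives 90.1%, the second highest of the three numbers, within the scatter of compound 2 and well beyond compound 1.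

The unmeasured compound 4 `COc1ccc(N)c(C2=NN(C(=O)C3CCC3)C(C)(C)S2)c1` differs from compound 3 in one place: cyclobutyl in place of cyclopropyl on a carbonyl carbon. Within the data shown here, two measured steps bear on this. a number 17.1 percentage points higher from compound 1 to compound 3 (beyond the scatter) shows that replacing ethyl with cyclopropyl on the carbonyl carbon raised inhibition, while a number 1 percentage points lower from compound 2 to compound 3 (within the scatter) shows that propyl and cyclopropyl cannot be told apart. A similar gain came from lengthening the chain, as a number 18.1 percentage points higher from compound 1 to compound 2 (beyond the scatter) shows. Because a number 1 percentage points lower from compound 2 to compound 3 (within the scatter) puts propyl and cyclopropyl at the same level, adding one carbon to the ring in compound 4 is expected to change little in this assay.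

Compound 4 is therefore expected to give about 90%, with a range from 78% to 97%. The expected step of a number 0.1 percentage points lower from compound 3 to compound 4 (within the scatter) is estimated to stay within the scatter.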

Compound 4, a percentage reported as inhibition, at one concentration (the size of the read-out at that concentration, not a potency): 57.8%
For compound 4 the middle estimate is 32.2 percentage points above the measured one; measured number outside the range, below it.
By their numbers in this assay, from the lowest: compound 4; then compound 1; then compounds 3 and 2 (each within the scatter of the next).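

In this assay, a larger group on this carbonyl carbon does not steadily bring more inhibition: one added ring carbon costs much of it (a number 32.3 percentage points lower from compound 3 to compound 4 (beyond the scatter)), and cyclobutyl also falls well short of the open propyl chain (a number 33.3 percentage points lower from compound 2 to compound 4 (beyond the scatter)). Cyclobutyl even ends up under the smaller ethyl group (a number 15.2 percentage points lower from compound 1 to compound 4 (beyond the scatter)), so the rise seen on going from ethyl to propyl or cyclopropyl does not carry on to this ring. The earlier compounds showed only a gain or no clear change at this place, and nothing at hand explains this drop.

A cyclopentyl ring, a butyl chain or a branched isopropyl group on the same carbonyl carbon would show whether inhibition keeps falling with larger groups. Such compounds would also show whether the loss is particular to cyclobutyl.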